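The source may hold more compounds than are shown below. What is called first, only, known or untested is meant among the compounds shown, and "the series" means these compounds.

For the measured compounds named here, compound 1 `O=C1/C(=C/c2ccccc2)Cc2cc(O)ccc21` gives 1940 nM in an assay on isolated protein for inhibition of Amine oxidase [flavin-containing] A (Homo sapiens), read by fluorescence and spectrophotometry, with a stated time of 20 min (on this read-out higher numbers stand for weaker inhibition and lower numbers for stronger inhibition), and stands highest of the two numbers measured so far. Compound 2 `O=C1/C(=C/c2cccc(F)c2)Cc2cc(O)ccc21` gives 458 nM in this assay. Going by the values given here, the only measured step, a 4.2-fold lower number from compound 1 to compound 2 (0.63 log units; beyond the scatter), puts one substituent on the same ring. Compound 3 `N#Cc1ccc(/C=C2\Cc3cc(O)ccc3C2=O)cc1` differs from compound 1 by cyano in place of hydrogen on an aromatic carbon. That step bears on the new one only as a precedent for substitution on this ring, and cyano is a different group, so a smaller lowering is expected for compound 3, namely a 2.2-fold lower number from compound 1 to compound 3 (0.33 log units; beyond the scatter). Compound 3 is therefore estimated at 900 nM, within a range from 300 nM to 2700 nM.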

Compound 3, half-maximal inhibitory concentration: 2080 nM
For compound 3 the middle estimate is 2.3-fold (0.36 log units) below the measured one; the range from low to high includes it.
By their numbers in this assay, from the lowest: compound 2; then compounds 1 and 3 (each within the scatter of the next).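

Cyano in place of hydrogen, para to a large group, gives a 1.1-fold higher number from compound 1 to compound 3 (0.03 log units; within the scatter) in this assay, so this substitution leaves the read-out within the scatter of compound 1. Set beside a 4.2-fold lower number from compound 1 to compound 2 (0.63 log units; beyond the scatter), this shows that putting a substituent on this ring does not by itself lower the number. Nothing available explains this result. The compounds shown leave open whether an amine or a methoxy group at this same place would lower the number in this assay as well.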